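Moving from 3-fluorophenyl to 2-chlorophenyl on the sulfonyl

The compounds below may be only part of what the source reports. "The series", "measured", "known", "first", "only" and "open" are said of these compounds alone.

Compound 2 `CN1CCC(n2cc(S(=O)(=O)c3cccc(F)c3)c3cccnc32)C1` gives the lowest of the two numbers in an assay on HeLa cells for displacement of a labelled ligand from 5-hydroxytryptamine receptor 6 (Homo sapiens) (a higher number here means a weaker inhibitor, a lower number a stronger inhibitor), namely 1.4 nM. Compound 1 `CN1CCC(n2cc(S(=O)(=O)c3ccccc3F)c3cccnc32)C1` gives 5.6 nM, and the change a 4.0-fold lower number from compound 1 to compound 2 (0.60 log units; beyond the scatter) lies beyond the scatter. Compound 3 `CN1CCC(n2cc(S(=O)(=O)c3ccccc3Cl)c3cccnc32)C1` carries the change (2-chlorophenyl in place of 3-fluorophenyl on a sulfonyl sulfur). Among the measured compounds shown here, only that one step bears on it: it returns the halogen to the position seen in compound 1, with chlorine instead of fluorine. A higher number is therefore expected for compound 3, with a step of a 3.6-fold higher number from compound 2 to compound 3 (0.55 log units; beyond the scatter), giving an estimate of 5 nM, between 1.5 nM and 20 nM.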

Compound 3, inhibition constant: 2.2 nM
Compound 3: middle estimate off by 2.3-fold (0.36 log units), on the high side; measured number inside the range.
By their numbers in this assay, from the lowest: compounds 2 and 3 (each within the scatter of the next); then compound 1.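

Within this assay the change from fluoro to chloro on an aromatic carbon gives a 2.5-fold lower number from compound 1 to compound 3 (0.41 log units; beyond the scatter) and so shows that the identity of the halogen matters on this ring, which the two fluorinated compounds could not show. With a 1.6-fold higher number from compound 2 to compound 3 (0.20 log units; within the scatter) the 2-chlorophenyl and 3-fluorophenyl groups on the sulfonyl sulfur cannot be told apart, so a halogen placed as in compound 1 does not by itself carry the higher number. Nothing measured here accounts for these steps.

Going by these compounds, it remains open how bromo or methoxy in place of chloro on that aromatic carbon would read, and how a plain phenyl on the sulfonyl sulfur compares.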